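Dropping a Methoxy Group: Will Inhibition Appear?

This account rests on a few compounds, and the source may have more. Where it says the series, first, only, none or still open, it means among the compounds named here.

Measured compounds:
compound 1, `COc1cc2oc(/C=C/[S+](C)[O-])cc(=O)c2cc1O`, gives > 10000 nM.
compound 2, `COc1ccc2c(=O)cc(/C=C/[S+](C)[O-])oc2c1OC`, gives > 10000 nM.
compound 3, `C[S+]([O-])/C=C/c1cc(=O)c2cc(O)ccc2o1`, gives > 10000 nM.

All three were tested in a functional assay on A549 cells (Homo sapiens) for inhibition, with a stated time of 48 h; on this read-out higher numbers stand for weaker inhibition and lower numbers for stronger inhibition. For compound 1 the value is a limit of the assay, not a number. The same holds for compound 2, whose value is also only a limit. Compound 3 likewise returns only a limit. Compound 1 and compound 3 differ by hydrogen in place of methoxy on an aromatic carbon, and the step between them is a step that the two limits leave unreadable from compound 1 to compound 3, which cannot be read because of the limit of > 10000 nM in this assay, at which 3 of the 3 values shown sit. The difference between the cores of compound 1 and compound 2 is not broken down here.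

The unmeasured compound 4, `COc1ccc2c(=O)cc(/C=C/[S+](C)[O-])oc2c1`, arises from compound 2 by hydrogen in place of methoxy on an aromatic carbon. Going by the values given here, this is the same kind of change as the one from compound 1 to compound 3, though the surroundings differ: in compound 1 the methoxy sits ortho to a hydroxy group (1 heavy atom), meta to a fused ring and para to a fused ring, whereas in compound 2 it sits ortho to a fused ring, ortho to a methoxy group (2 heavy atoms) and meta to a fused ring.

Among the compounds with values here, since every measured value in this assay is a limit, the only available comparison gives no readable size, and compound 4 is expected to stay at a limit as well, so the expected step is a step that the limit leaves unreadable from compound 2 to compound 4. Compound 4 is therefore estimated at 15000 nM, within 5000 nM to 50000 nM.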

Compound 4, half-maximal inhibitory concentration: 10500 nM
The estimate for compound 4 lay 1.4-fold (0.15 log units) above the measured number, within the range that was stated.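

No new step can be read for compound 4, whether from compound 2 or from compound 1, because the values of those two compounds are limits and not numbers: the limit of > 10000 nM in this assay, at which 3 of the 4 values shown sit.

The compounds shown leave open how far compound 1, compound 2 and compound 3 truly lie from compound 4 in this assay, and so whether hydrogen in place of methoxy strengthens inhibition, weakens it or leaves it unchanged.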